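A few compounds are considered here, and "the series" means these few. Any claim that something is new, unique, unknown or untested is made for them only; others in the source may bear on it.

Measured so far in a functional assay on HepG2 cells (Homo sapiens) for cytotoxicity, read by MTT assay, with a stated time of 48 h; a lower number here means a stronger inhibitor, a higher number a weaker inhibitor
compound 1 `COc1cc(/C=C/C(=O)/C=C/c2nc3cc(O)ccc3n2C)ccc1O` gives 3600 nM
compound 2 `COc1ccc(/C=C/C(=O)/C=C/c2nc3ccccc3n2C)cc1O` gives 2900 nM
compound 3 `COc1ccc(/C=C/C(=O)/C=C/c2nc3cc(C)ccc3n2C)cc1O` gives 3300 nM

Compound 3, at 3300 nM in this assay, lies within the scatter of both compound 1 and compound 2, so these numbers give no order among the three.

Going from compound 3 to compound 4 `COc1ccc(/C=C/C(=O)/C=C/c2nc3c(C)c(C)ccc3n2C)cc1O` brings methyl in place of hydrogen on an aromatic carbon and the new methyl sits on an aromatic carbon, ortho to a methyl group and ortho to a fused ring. Within the data shown here, one measured step bears on this, the same replacement of hydrogen by methyl on an aromatic carbon: a 1.1-fold higher number from compound 2 to compound 3 (0.06 log units; within the scatter) and that step stays within the scatter. Among the measured compounds shown here, no measured step has a methyl group placed ortho to a methyl group, so this is a single and indirect guide, and the range is kept wide.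

In this assay no step beyond the scatter is expected, in either direction. The expected step is a 1.0-fold lower number from compound 3 to compound 4 (0.01 log units; within the scatter) and it remains an estimate. For compound 4 the estimated value is 3200 nM with an expected range from 1800 nM to 5800 nM on repeated measurement.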

Compound 4, half-maximal inhibitory concentration: 3900 nM
Beside the measured number, compound 4's estimate is 1.2-fold (0.09 log units) below it, within the range that was stated.
By their numbers in this assay, from the lowest: compounds 2, 3, 1 and 4 (each within the scatter of the next).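

In this assay, the new methyl on an aromatic carbon, ortho to a methyl group and ortho to a fused ring, gives a 1.2-fold higher number from compound 3 to compound 4 (0.07 log units; within the scatter). Among these compounds, the only earlier guide for this replacement was a 1.1-fold higher number from compound 2 to compound 3 (0.06 log units; within the scatter), at a different place on the ring and with no methyl group ortho to it; compound 4 now shows that a methyl at this position, ortho to a methyl group, also stays within the scatter. No accompanying measurement is available to explain the size of this step.

Among the compounds shown here, whether an amine, a carboxylic acid or a longer chain such as propyl at this position would give a step beyond the scatter remains open, since methyl is the only group entering here. No step shown so far in this assay lies beyond the scatter, so it also remains open which part of the shared core, if any, governs the number.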